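Urea versus Amide on a Pyrazole Growth Inhibitor Series

The source may hold more compounds than are shown below. What is called first, only, known or untested is meant among the compounds shown, and "the series" means these compounds.

Measured compounds:
compound 1 `COc1cc(-c2nn(-c3cccc(NC(=O)Nc4cc(C(F)(F)F)cc(C(F)(F)F)c4)c3)cc2-c2ccncc2)ccc1Cl` with 1230 nM
compound 2 `COc1cc(-c2nn(-c3cccc(NC(=O)c4cccc(C(F)(F)F)c4)c3)cc2-c2ccncc2)ccc1Cl` with 2980 nM

In a functional assay on OVCAR-3 cells (Homo sapiens) for inhibition, read by sulforhodamine B assay, with a stated time of 48 h (on this read-out higher numbers stand for weaker inhibition of growth and lower numbers for stronger inhibition of growth), compound 1 gives 1230 nM. In this assay compound 2 gives 2980 nM, the highest of the two numbers shown, and its distance to compound 1 lies beyond the usual scatter, so compound 1 stands as the stronger growth inhibitor of the pair. For the measured compounds named here, no step between these two compounds is computed here; only their two values are known.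

Compound 3 `COc1cc(-c2nn(-c3cccc(NC(=O)Nc4ccc(Cl)c(C(F)(F)F)c4)c3)cc2-c2ccncc2)ccc1Cl` has not yet been measured. It differs from compound 2 in one place: (4-chloro-3-(trifluoromethyl)phenyl)amino in place of 3-(trifluoromethyl)phenyl on a carbonyl carbon. Through this change compound 3 acquires an amino group on the carbonyl carbon, as compound 1 has, so it is expected to move away from compound 2 and toward the number seen for compound 1, which gives 1230 nM. The step from compound 2 to compound 3 is therefore expected to be a 2.1-fold lower number from compound 2 to compound 3 (0.33 log units; beyond the scatter), toward stronger inhibition. For compound 3 the estimated value in this assay is 1400 nM, with a range from 500 nM to 4000 nM.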

Compound 3, concentration for total growth inhibition: 2440 nM
Estimate against measurement, compound 3: 1.7-fold (0.24 log units) below; the range from low to high includes it.
By their numbers in this assay, from the lowest: compounds 1, 3 and 2 (each within the scatter of the next, the first and the last beyond it).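

In this assay, putting (4-chloro-3-(trifluoromethyl)phenyl)amino in place of 3-(trifluoromethyl)phenyl on a carbonyl carbon gives a 1.2-fold lower number from compound 2 to compound 3 (0.09 log units; within the scatter), so this double alteration, which turns the amide into a urea and adds a chlorine, leaves no readable change at this position. Compound 3 shares the amino group on the carbonyl carbon with compound 1, yet its number lies within the scatter of both compound 1 and compound 2, so the presence of that amino group is not enough to show what separates compound 1 from compound 2. Nothing given here explains this outcome.

The step changes the amino group and the chlorine together, so the contribution of each stays unresolved, and only a urea carrying 3-(trifluoromethyl)phenyl or an amide carrying 4-chloro-3-(trifluoromethyl)phenyl could separate them. It also remains open whether a fluorine, a methyl or a methoxy group in place of the chlorine, or a methylene in place of the amino group, would give a number different from those of these compounds.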